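A few compounds are considered here, and "the series" means these few. Any claim that something is new, unique, unknown or untested is made for them only; others in the source may bear on it.

Working notes on the series, read in a functional assay on HepG2 cells (Homo sapiens) for cytotoxicity, read by MTT assay, with a stated time of 48 h; a higher number here means a weaker inhibitor, a lower number a stronger inhibitor. Going by the values given here, compound 1 `COC(=O)/C=C/c1ccc2c(c1)C(=O)C(=O)N2Cc1cc(C)cc(C)c1` gives 150 nM, the only actual number so far. Compound 2 `COC(=O)/C=C/c1ccc2c(c1)N(Cc1ccc(OC)cc1)C(=O)C2=O` reads > 10000 nM, which is a limit of the assay and not a number. Compound 3 `COC(=O)/C=C/c1cccc2c1N(Cc1ccc(OC)cc1)C(=O)C2=O` reads > 10000 nM, again a limit and not a number. Taken together, the picture is the limit of > 10000 nM in this assay, at which 2 of the 3 values shown sit. Among the compounds with values here, no two measured compounds differ in one place only, so no measured step is available to calibrate the next change.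

Compound 4 `COC(=O)/C=C/c1ccc2c(c1)C(=O)C(=O)N2Cc1ccc(C)cc1` keeps the core of compound 1 and carries 4-methylphenyl in place of 3,5-dimethylphenyl on a saturated chain carbon bound to an amide-type nitrogen in a ring. Within the data shown here, with no single-change precedent, the expectation is anchored on compound 1 at 150 nM and remains loose. A moderate loss of strength in this assay is expected, beyond the usual scatter but well short of complete loss, though a reading at the limit cannot be excluded. The estimated step is a 4.0-fold higher number from compound 1 to compound 4 (0.60 log units; beyond the scatter). The expected value for compound 4 is 600 nM. The estimated range for this compound runs from 120 nM to 6000 nM.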

Compound 4, half-maximal inhibitory concentration: 40 nM
The estimate for compound 4 lay 15-fold (1.18 log units) above the measured number; measured number below the stated range.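

This position, on a saturated chain carbon bound to an amide-type nitrogen in a ring, now has its first measured single change: in this assay, 4-methylphenyl in place of 3,5-dimethylphenyl gives a 3.8-fold lower number from compound 1 to compound 4 (0.57 log units; beyond the scatter). The strength of compound 1 therefore does not depend on keeping 3,5-dimethylphenyl, and this position accepts a change of the substitution on the aromatic ring with the number moving down rather than up, though a single pair shows this for these two groups only. Nothing measured here bears on why the step runs in this direction.

As far as these compounds go, whether the trend extends to other groups at this position remains open, for example plain phenyl, 4-chlorophenyl, or a longer chain in place of the saturated chain carbon. Compound 2 and compound 3 each differ from compound 4 in more than one place and each reads at a limit of the assay, not a number, so what separates them from compound 1 and compound 4 cannot be read from the compounds shown.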